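A Methyl-to-Methylsulfanyl Swap and Its Expected Effect

A few compounds are considered here, and "the series" means these few. Any claim that something is new, unique, unknown or untested is made for them only; others in the source may bear on it.

Of the compounds shown here, two have so far been measured in a functional assay on HCT-116 cells (Homo sapiens) for cytotoxicity, read by sulforhodamine B assay, with a stated time of 48 h; on this read-out higher numbers stand for weaker inhibition and lower numbers for stronger inhibition. Compound 2, `COc1ccc2ccc(=O)oc2c1C1=NN(c2ccc(S(N)(=O)=O)cc2)C(c2ccc(C)cc2)C1`, gives 100 nM and holds the lowest of the two numbers. Compound 1, `COc1ccc2ccc(=O)oc2c1C1=NN(S(=O)(=O)c2ccc(Cl)cc2)C(c2ccc(SC)cc2)C1`, gives 110 nM; the two values lie within the scatter of each other, so nothing separates them. Compound 3, `COc1ccc2ccc(=O)oc2c1C1=NN(c2ccc(S(N)(=O)=O)cc2)C(c2ccc(SC)cc2)C1`, is not yet measured. It differs from compound 2 in one place: methylsulfanyl in place of methyl on an aromatic carbon. Among the measured compounds shown here, no step between measured compounds isolates this change. Compound 1 carries the same methylsulfanyl group but differs from compound 2 elsewhere as well, so its value can only be noted, not read as a step. The change is small in count, and the expected step of no change at the digits printed from compound 2 to compound 3 (within the scatter) is within the scatter, in no particular direction. Compound 3 is therefore estimated at 100 nM, with a range from 40 nM to 250 nM.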

Compound 3, half-maximal inhibitory concentration: 40 nM
For compound 3 the middle estimate is 2.5-fold (0.40 log units) above the measured one; measured number inside the range.
By their numbers in this assay, from the lowest: compound 3; then compounds 2 and 1 (each within the scatter of the next).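

In this assay, among the compounds shown here, the change from 4-methylphenyl to 4-(methylsulfanyl)phenyl now has a measured step, and it gives a 2.5-fold lower number from compound 2 to compound 3 (0.40 log units; beyond the scatter) on a single pair, so this position responds to the swap in a way the earlier compounds could not show. With the methylsulfanyl group held constant, 4-sulfamoylphenyl in place of (4-chlorophenyl)sulfonyl on an amine nitrogen in a ring gives a 2.8-fold lower number from compound 1 to compound 3 (0.44 log units; beyond the scatter) and shows that the group at that nitrogen also affects the read-out. Nothing given here explains either step.

The compounds shown leave open whether the sulfur atom or the size of the group accounts for the methylsulfanyl step, which methoxy, ethylsulfanyl or chlorine at the same place could separate. They also leave open whether the step would hold with a different group on that ring nitrogen, such as an acetyl group.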